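The source may hold more compounds than are shown below. What is called first, only, known or untested is meant among the compounds shown, and "the series" means these compounds.

Compound 1 `CCCn1c(=O)[nH]c2nc(-c3ccc(S(=O)(=O)N4CCN(c5ccc(F)cc5)CC4)cc3)[nH]c2c1=O` gives > 1000 nM in an assay on CHO cells for displacement of a labelled ligand from adenosine receptor A3 (Homo sapiens), read by scintillation counting, with a stated time of 45 min, in the presence of a further agent that is not named here; on this read-out lower numbers stand for stronger inhibition and higher numbers for weaker inhibition; this is a limit of the assay, not a number.
Compound 2 `CCCn1c(=O)[nH]c2nc(-c3ccc(S(=O)(=O)N4CCN(c5ccc(Br)cc5)CC4)cc3)[nH]c2c1=O` gives > 1000 nM in this assay, again only a limit of the assay.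
Compound 3 `CCCn1c(=O)[nH]c2nc(-c3ccc(S(=O)(=O)N4CCN(c5ccccc5Br)CC4)cc3)[nH]c2c1=O` gives > 1000 nM in this assay, again only a limit of the assay.

Compound 1 therefore has no definite place among these numbers: its own value is a limit, and the two other values shown are limits as well, all three sitting at the limit of > 1000 nM in this assay, at which 3 of the 3 values shown sit. The steps between the measured compounds, a step that the two limits leave unreadable from compound 1 to compound 2, a step that the two limits leave unreadable from compound 1 to compound 3 and a step that the two limits leave unreadable from compound 2 to compound 3, cannot be read in size or direction because every value involved rests at the limit of > 1000 nM in this assay, at which 3 of the 3 values shown sit. The exchanges they cover, bromo for fluoro and a shift of the bromine around the aryl ring on the piperazine nitrogen, thus leave no readable trace.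

Compound 4 `CCCn1c(=O)[nH]c2nc(-c3ccc(S(=O)(=O)N4CCN(c5cccc(Br)c5)CC4)cc3)[nH]c2c1=O` has not yet been measured. It differs from compound 1 as follows: 3-bromophenyl in place of 4-fluorophenyl on an amine nitrogen in a ring. This change is of the same kind as the unreadable ones already seen, so no step beyond the usual scatter can be grounded in the data. Compound 4 is expected to give 3000 nM in this assay, with a range from 1000 nM to 10000 nM, most likely reported again only as a limit. The expected step is a step that the limit leaves unreadable from compound 1 to compound 4.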

Compound 4, inhibition constant: > 1000 nM
Compound 4: a limit, no number (the forecaster's own chance of this, stated with the estimate: 85%); the middle value does not contradict the limit.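

Compound 4 gives > 1000 nM in this assay, which is again a limit of the assay and not a number. For the compounds shown here, no step from compound 4 to compound 1, compound 2 or compound 3 can be read, because every value rests at the same limit: the limit of > 1000 nM in this assay, at which 4 of the 4 values shown sit. The compounds shown leave open how strongly each one actually inhibits, and whether exchanging fluoro for bromo or moving the bromine around the phenyl ring changes anything.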